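A few compounds are considered here, and "the series" means these few. Any claim that something is new, unique, unknown or untested is made for them only; others in the source may bear on it.

In a functional assay on HL-60 cells (Homo sapiens) for antiproliferative activity (a lower number here means a stronger inhibitor of growth, a higher number a weaker inhibitor of growth), compound 1 `COC(=O)CCCCCCCCCCCCCC/C=C1\CC(CO)(COC(=O)C(C)(C)C)OC1=O` gives > 10 ug/mL, which is a limit of the assay and not a number. Compound 2 `CC(C)(C)C(=O)OCC1(CO)C/C(=C\CCCCCCCCCCCCCCC=O)C(=O)O1` gives > 10 ug/mL, which is likewise a limit. Among the compounds with values here, compound 2 therefore has no exact position, and the series so far amounts to the limit of > 10 ug/mL in this assay, at which 2 of the 2 values shown sit. Within the data shown here, the only measured step is a step that the two limits leave unreadable from compound 1 to compound 2, with hydrogen in place of methoxy on a carbonyl carbon, so it offers no size to carry forward.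

Compound 3 `CC(=O)OCCCCCCCCCCCCCCC/C=C1\CC(CO)(COC(=O)C(C)(C)C)OC1=O` keeps the shared core and alters the far end of the long chain: acetoxymethyl in place of formyl on a saturated chain carbon, ten or more bonds along the chain from a double-bonded chain carbon. This places acetoxymethyl in place of formyl on a saturated chain carbon, ten or more bonds along the chain from a double-bonded chain carbon. The expectation rests on compound 2, whose > 10 ug/mL is a limit, and on the unreadable step at this end of the chain. No step beyond the scatter can be predicted in this assay, and another reading at the limit is expected to be the likeliest result. The estimated change is a step that the limit leaves unreadable from compound 2 to compound 3. Compound 3 is expected at 15 ug/mL, with an estimated range of 6 ug/mL to 40 ug/mL.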

Compound 3, concentration for 50% growth inhibition: > 10 ug/mL
Compound 3 ended at the assay's limit (the forecaster's own chance of this, stated with the estimate: 75%); the middle value lies beyond the limit too.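

No new step can be read: in this assay compound 3 gives only a limit, so its steps from compound 1 and compound 2 remain unreadable. The series remains at one limit: the limit of > 10 ug/mL in this assay, at which 3 of the 3 values shown sit. The compounds shown leave open whether any change at the far end of the long chain alters growth inhibition.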